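The source may report more compounds than this note shows. Statements on the series, on what has been measured and on what is new or still open speak of the compounds shown alone.

Compound 1 `COc1ccc([C@@H]2CC(=O)c3c(O)cc(OCc4cn(Cc5ccc(C(F)(F)F)cc5)nn4)cc3O2)cc1O` gives 17700 nM
Compound 2 `COc1ccc([C@@H]2CC(=O)c3c(O)cc(OCc4cn(Cc5ccccc5C(F)(F)F)nn4)cc3O2)cc1O` gives 12500 nM
Compound 3 `CCCn1cc(COc2cc(O)c3c(c2)O[C@H](c2ccc(OC)c(O)c2)C/C3=N\O)nn1` gives 2340 nM

These numbers come from a functional assay on RAW264.7 cells (Mus musculus) for inhibition, read by Griess assay, with stated times of 2 h and 24 h (a higher number here means a weaker inhibitor, a lower number a stronger inhibitor), and place compound 1 with compound 2 at the high-number end of the three, the pair lying within the scatter of each other. Compound 3 sits lower than compound 1, by more than the scatter.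

Compound 4 `COc1ccc([C@@H]2CC(=O)c3c(O)cc(OCc4cn(CC5CC5)nn4)cc3O2)cc1O` keeps the core of compound 1 and changes one group (cyclopropyl in place of 4-(trifluoromethyl)phenyl on a saturated chain carbon bound to an aromatic nitrogen), with cyclopropyl in place of 4-(trifluoromethyl)phenyl on a saturated chain carbon bound to an aromatic nitrogen.

For the measured compounds named here, only one measured step touches this place (a 1.4-fold lower number from compound 1 to compound 2 (0.15 log units; within the scatter)) and it stayed within the scatter. That step keeps a phenyl ring carrying trifluoromethyl, however, while compound 4 loses that ring, so it is only a loose guide. Compound 3 at 2340 nM shows that lower numbers occur in this small set, but it differs from compound 1 in more than one place, so it supports only a slight lean downward.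

The expected step is a 1.8-fold lower number from compound 1 to compound 4 (0.25 log units; within the scatter) and no shift beyond the scatter is firmly expected. For compound 4 the estimated value is 10000 nM with a wide expected range (3500 nM to 30000 nM).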

Compound 4, half-maximal inhibitory concentration: 11900 nM
For compound 4 the middle estimate is 1.2-fold (0.08 log units) below the measured one; the range from low to high includes it.
By their numbers in this assay, from the lowest: compound 3; then compounds 4, 2 and 1 (each within the scatter of the next).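

In this assay, cyclopropyl in place of 4-(trifluoromethyl)phenyl gives a 1.5-fold lower number from compound 1 to compound 4 (0.17 log units; within the scatter), and cyclopropyl in place of 2-(trifluoromethyl)phenyl gives a 1.1-fold lower number from compound 2 to compound 4 (0.02 log units; within the scatter), so neither step separates the compounds it joins. The earlier step only exchanged one trifluoromethyl-bearing phenyl ring for another, whereas these steps show that the whole ring can give way to a three-membered carbon ring, and the reading stays within the scatter for these three compounds. No measurement at hand explains why these compounds read alike.

Compound 3, at 2340 nM, differs from compound 1 in more than one place, so its value cannot be assigned to any single group. As far as these compounds go, it remains open whether a group of another kind on this saturated chain carbon, such as an amine, a carboxylic acid or a longer carbon chain, would move the number beyond the scatter, or whether this position simply has little bearing on the reading.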